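Dropping the chloro from the hydrazone aryl ring

The source may hold more compounds than are shown below. What is called first, only, known or untested is meant among the compounds shown, and "the series" means these compounds.

Compound 3 `Cc1c(C(=O)N/N=C\c2c(O)cccc2Cl)oc2cccc(O)c12` gives 18700 nM in a functional assay on PC-3 cells (Homo sapiens) for inhibition (a lower number here means a stronger inhibitor, a higher number a weaker inhibitor), the highest of the two numbers in the series. Compound 2 `Cc1ccc(O)c(/C=N\NC(=O)c2oc3cccc(O)c3c2C)c1` gives 7350 nM. Compound 1 `Cc1c(C(=O)N/N=C\c2ccccn2)oc2cccc(O)c12` reaches only the limit >= 40000 nM, which is a limit of the assay and not a number. Compound 4 `Cc1c(C(=O)N/N=C\c2ccccc2O)oc2cccc(O)c12` is still unmeasured; it differs from compound 3 by hydrogen in place of chloro on an aromatic carbon. The steps of an at least 5.4-fold lower number from compound 1 to compound 2 (0.73 log units; beyond the scatter) and an at least 2.1-fold lower number from compound 1 to compound 3 (0.33 log units; beyond the scatter) show both hydroxyphenyl groups beating pyridin-2-yl, while a 2.5-fold higher number from compound 2 to compound 3 (0.41 log units; beyond the scatter) shows a modest loss on moving to the chloro-bearing ring. For the measured compounds named here, no measured step isolates the chloro alone. Compound 4 is therefore expected to show a small change, a 1.3-fold lower number from compound 3 to compound 4 (0.13 log units; within the scatter), staying within the scatter of its parent. The estimate for compound 4 is 14000 nM, between 5000 nM and 40000 nM.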

Compound 4, half-maximal inhibitory concentration: 8350 nM
For compound 4 the middle estimate is 1.7-fold (0.22 log units) above the measured one; the measured number falls inside the stated range.
By their numbers in this assay, from the lowest: compounds 2 and 4 (each within the scatter of the next); then compound 3. At a limit, above all of these: compound 1.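

In this assay, for the compounds shown here, the chloro is now isolated at this position for the first time, and hydrogen in its place gives a 2.2-fold lower number from compound 3 to compound 4 (0.35 log units; beyond the scatter). Hydrogen in place of methyl gives a 1.1-fold higher number from compound 2 to compound 4 (0.06 log units; within the scatter), so that change, unlike the chloro change, stays within the scatter. The comparison with pyridin-2-yl, an at least 4.7-fold lower number from compound 1 to compound 4 (0.68 log units; beyond the scatter), rests on the value of compound 1, which is a limit of the assay and not a number: the limit of >= 40000 nM in this assay, at which 1 of the 4 values shown sits.

As far as these compounds go, whether the loss is particular to chloro remains open. An amine or a methoxy group at this position could separate the two readings.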